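Working notes: stepping from compound 3 to compound 4

A few compounds are considered here, and "the series" means these few. Any claim that something is new, unique, unknown or untested is made for them only; others in the source may bear on it.

Values so far in a functional assay on HeLa cells (Homo sapiens) for inhibition, read by CCK-8 assay, with a stated time of 72 h, tested at 2 uM (a higher number here means more inhibition of growth at the concentration tested, a lower number less inhibition of growth), are as follows
- compound 1 `CCc1ccc(SCc2ccc(C(=O)Nc3ccccc3N)cc2)cc1` gives 30.8%
- compound 2 `Nc1ccccc1NC(=O)c1ccc(CSc2ccc(Br)cc2)cc1` gives 18.8%
- compound 3 `Nc1ccccc1NC(=O)c1ccc(CSc2ccc(F)cc2)cc1` gives 27.9%

Compound 3 stands within the scatter of both other compounds (a number 2.9 percentage points lower from compound 1 to compound 3 (within the scatter); a number 9.1 percentage points higher from compound 2 to compound 3 (within the scatter)). The next structure is compound 4 `Cc1cc(C)cc(SCc2ccc(C(=O)Nc3ccccc3N)cc2)c1` and the change is 3,5-dimethylphenyl in place of 4-fluorophenyl on a sulfur with 3,5-dimethylphenyl in place of 4-fluorophenyl on a sulfur. Among the measured compounds shown here, no measured compound carries 3,5-dimethylphenyl, so the evidence is indirect. For the measured compounds named here, the only measured swaps are single substituent changes, and the one step beyond the scatter is modest (a number 12 percentage points lower from compound 1 to compound 2 (beyond the scatter)). Compound 1, with ethyl as its substituent, offers the closest comparison and shows no separation from compound 3 (a number 2.9 percentage points lower from compound 1 to compound 3 (within the scatter)). A step of similar small size is therefore expected, with no direction beyond the scatter (a number 1.1 percentage points higher from compound 3 to compound 4 (within the scatter)). The value expected for compound 4 is 29% (estimated range 17% to 41%).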

Compound 4, percent growth inhibition at one concentration: 40.2%
Estimate against measurement, compound 4: 11.2 percentage points below; measured number inside the range.
By their numbers in this assay, from the lowest: compounds 2, 3, 1 and 4 (each within the scatter of the next, the first and the last beyond it).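

In this assay, among the compounds shown here, the group on the sulfur can move the number upward beyond the scatter, which no earlier step showed: a number 12.3 percentage points higher from compound 3 to compound 4 (beyond the scatter), and a number 21.4 percentage points higher from compound 2 to compound 4 (beyond the scatter). Both steps put 3,5-dimethylphenyl in place of a halogen-bearing phenyl, yet the change to 3,5-dimethylphenyl from 4-ethylphenyl stays unresolved, a number 9.4 percentage points higher from compound 1 to compound 4 (within the scatter), so compound 4 does not separate from compound 1. Nothing on hand accounts for these steps.

Open, on these data alone, is whether a phenyl carrying a single methyl would read like 3,5-dimethylphenyl, and how a methoxy, an amine or a carboxylic acid on that ring would read. Also open, as far as these compounds go, is whether this order of compounds holds in any other cell line.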